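A few compounds are considered here, and "the series" means these few. Any claim that something is new, unique, unknown or untested is made for them only; others in the source may bear on it.

Compound 1 `C=CCOCC(N)C(=O)NCc1ccccc1` is one of three benzylamides tested in a functional assay on the whole organism (strain NMRI) with Mus musculus as the target, in the maximal electroshock model, with a stated time of 30 min; a higher number here means that more compound is needed for the effect, a lower number that less compound is needed. Here compound 1 gives 45 mg/kg, the highest of the three numbers. Compound 3 `CCCC[C@@H](N)C(=O)NCc1ccccc1` gives 23 mg/kg, a value within the scatter of compound 1, while compound 2 `CC(C)(C)[C@@H](N)C(=O)NCc1ccccc1` gives 13 mg/kg, a gap from compound 1 that goes beyond the scatter. Between the two measured alkyl compounds the step of a 1.8-fold higher number from compound 2 to compound 3 (0.25 log units; within the scatter) stays within the scatter, so exchanging one alkyl chain for another did not move the number much. Compound 4 `CCCC(N)C(=O)NCc1ccccc1` is not yet measured; it differs from compound 1 by ethyl in place of allyloxy on a saturated chain carbon, two bonds along the chain from an amine nitrogen and a carbonyl carbon. The change removes the ether oxygen and the double bond and leaves a plain alkyl chain, like those of compound 2 and compound 3. Given compound 3 at 23 mg/kg and compound 2 at 13 mg/kg, compound 4 is expected to land near those two, with a step of a 1.5-fold lower number from compound 1 to compound 4 (0.18 log units; within the scatter) expected toward a lower number. The estimate for compound 4 is 30 mg/kg, with a range from 15 mg/kg to 60 mg/kg.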

Compound 4, dose for half-maximal effect: 39 mg/kg
For compound 4 the middle estimate is 1.3-fold (0.11 log units) below the measured one; low and high end bracket the measured number.
By their numbers in this assay, from the lowest: compounds 2, 3, 4 and 1 (each within the scatter of the next, the first and the last beyond it).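

In this assay, the exchange of allyloxy for ethyl gives a 1.2-fold lower number from compound 1 to compound 4 (0.06 log units; within the scatter), which lies within the scatter. Within the data shown here, this is the first step that starts from compound 1, and it shows that at this saturated chain carbon, the ether oxygen and the double bond can leave together, and the group can drop from 4 heavy atoms to 2, without a readable change in the number. Nothing measured here explains this result.

From the compounds shown here alone, the oxygen and the double bond leave in the same step, so their separate roles stay open: a methoxy group would keep only the ether oxygen, and an allyl group only the double bond. Going by these compounds, it also remains open whether an amine or a carboxylic acid at this place would move the number beyond the scatter.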